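The compounds below may be only part of what the source reports. "The series", "measured", "known", "first", "only" and "open" are said of these compounds alone.

Compound 2 `COc1cc(C2=CC(=O)N3C[C@H](O[C@H](C)c4cc(C(F)(F)F)cc(C(F)(F)F)c4)[C@@H](c4ccc(F)cc4)C3C2)ccn1` gives 44 nM in an assay on CHO cells for displacement of a labelled ligand from Substance-P receptor (Homo sapiens), in the presence of a further agent that is not named here (on this read-out lower numbers stand for stronger inhibition and higher numbers for weaker inhibition), the lowest of the two numbers available, though compound 1 `C[C@@H](O[C@H]1CN2C(=O)C=C(c3ccc(C#N)cc3)CC2[C@@H]1c1ccc(F)cc1)c1cc(C(F)(F)F)cc(C(F)(F)F)c1`, which gives 53 nM in this assay , lies within the scatter of it. Compound 3 `C[C@@H](O[C@H]1CN2C(=O)C=C(c3cnn(Cc4ccccc4)c3)CC2[C@@H]1c1ccc(F)cc1)c1cc(C(F)(F)F)cc(C(F)(F)F)c1` differs from compound 2 by 1-benzyl-1H-pyrazol-4-yl in place of 2-methoxypyridin-4-yl on a double-bonded ring carbon. Among the compounds with values here, the one measured step that bears on this place, a 1.2-fold lower number from compound 1 to compound 2 (0.08 log units; within the scatter), also exchanged the aromatic group there and moved the number little. The new step is therefore expected to be small as well, with perhaps a slightly higher number: a 1.6-fold higher number from compound 2 to compound 3 (0.20 log units; within the scatter). Compound 3 is estimated at 70 nM, between 20 nM and 250 nM.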

Compound 3, half-maximal inhibitory concentration: 66 nM
Estimate against measurement, compound 3: 1.1-fold (0.03 log units) above; low and high end bracket the measured number.
By their numbers in this assay, from the lowest: compounds 2, 1 and 3 (each within the scatter of the next).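

At the place on the double-bonded ring carbon, 1-benzyl-1H-pyrazol-4-yl, which adds a second aromatic ring, gives a 1.5-fold higher number from compound 2 to compound 3 (0.18 log units; within the scatter), and against 4-cyanophenyl it gives a 1.2-fold higher number from compound 1 to compound 3 (0.10 log units; within the scatter). So the earlier exchange of one six-membered aromatic ring for another now extends to a five-membered aromatic ring carrying a benzyl group, with the number still inside the scatter. Nothing measured here says why the number holds so steady. As far as these compounds go, whether a group without an aromatic ring, such as a morpholine or a carboxylic acid, would also hold the number at this place remains open.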